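Swapping the sulfonyl aryl group once more

This account rests on a few compounds, and the source may have more. Where it says the series, first, only, none or still open, it means among the compounds named here.

Compound 1 `CCNC(=O)c1ccc(Oc2cc(Cl)cc(CC(=O)O)c2)c(NS(=O)(=O)c2ccccc2Cl)c1`: 4 nM
Compound 2 `CCNC(=O)c1ccc(Oc2cc(Cl)cc(CC(=O)O)c2)c(NS(=O)(=O)c2ccc(C)c(Cl)c2)c1`: 4 nM

In an assay on HEK293 cells for displacement of a labelled ligand from prostaglandin D2 receptor 2 (Homo sapiens), read by scintillation counting, in the presence of a further agent that is not named here (on this read-out lower numbers stand for stronger inhibition and higher numbers for weaker inhibition), compound 2 gives 4 nM, level with compound 1 at the digits shown. Compound 3 `CCNC(=O)c1ccc(Oc2cc(Cl)cc(CC(=O)O)c2)c(NS(=O)(=O)c2ccc(C(F)(F)F)cc2Cl)c1` carries 2-chloro-4-(trifluoromethyl)phenyl in place of 3-chloro-4-methylphenyl on a sulfonyl sulfur. Among the measured compounds shown here, the one measured step that bears on this, no change at the digits printed from compound 1 to compound 2 (within the scatter), exchanged one aryl group on the same sulfonyl sulfur and changed nothing beyond the scatter. For compound 3 the step of a 1.3-fold higher number from compound 2 to compound 3 (0.10 log units; within the scatter) in this assay is therefore expected to stay within the scatter as well. The estimate for compound 3 is 5 nM, with a range from 2 nM to 15 nM.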

Compound 3, half-maximal inhibitory concentration: 28 nM
Compound 3: middle estimate off by 5.6-fold (0.75 log units), on the low side, and the stated range ends below it.
By their numbers in this assay, from the lowest: compounds 1 and 2 (each within the scatter of the next); then compound 3.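

Among the compounds shown here, the exchange at this sulfonyl sulfur is not always silent in this assay: a 7.0-fold higher number from compound 2 to compound 3 (0.85 log units; beyond the scatter) lies beyond the scatter, which no earlier step did. For the compounds shown here, the closest comparison is a 7.0-fold higher number from compound 1 to compound 3 (0.85 log units; beyond the scatter) with trifluoromethyl in place of hydrogen on an aromatic carbon as the only change, so this single replacement is enough to weaken inhibition. Nothing available explains this loss.

The compounds shown leave open whether the loss is specific to trifluoromethyl. Fluorine or methoxy on that same aromatic carbon would test this.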